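Methyl in place of hydroxy: compound 2 to compound 3

The compounds below may be only part of what the source reports. "The series", "measured", "known", "first", "only" and "open" are said of these compounds alone.

In a functional assay on MCF7 cells (Homo sapiens) for antiproliferative activity, read by MTT assay, with a stated time of 72 h (a lower number here means a stronger inhibitor, a higher number a weaker inhibitor), compound 1 `Nc1nc(N)c2cc(CSC(=S)N3CCN(C4CCCCC4)CC3)ccc2n1` gives 6800 nM and compound 2 `Nc1nc(N)c2cc(CSC(=S)N3CCN(c4ccc(O)cc4)CC3)ccc2n1` gives 5090 nM. The two values lie within the scatter of each other, so compound 2 stands level with compound 1 on the numbers available. Compound 3 `Cc1ccc(N2CCN(C(=S)SCc3ccc4nc(N)nc(N)c4c3)CC2)cc1` has methyl in place of hydroxy on an aromatic carbon, para to a large group, which turns 4-hydroxyphenyl into 4-methylphenyl: methyl in place of hydroxy on an aromatic carbon.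

Going by the values given here, no measured step makes this exact exchange. Among the compounds with values here, the only step that bears on it is the one at the same substituent, where 4-hydroxyphenyl stands in place of cyclohexyl on an amine nitrogen in a ring: a 1.3-fold lower number from compound 1 to compound 2 (0.13 log units; within the scatter). That step stays within the scatter, and it is a single step, so it gives only weak guidance. Nothing in these data points to a change beyond the scatter in this assay, and no direction is favoured. The expected step is small, estimated as a 1.1-fold higher number from compound 2 to compound 3 (0.03 log units; within the scatter). Compound 3 is expected at 5500 nM, with an estimated range of 2500 nM to 12000 nM.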

Compound 3, half-maximal inhibitory concentration: 2480 nM
Compound 3: middle estimate off by 2.2-fold (0.35 log units), on the high side; the whole stated range lies above it.
By their numbers in this assay, from the lowest: compound 3; then compounds 2 and 1 (each within the scatter of the next).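

In this assay, going by these compounds alone, the group on the aromatic ring now gives a step beyond the scatter for the first time: methyl in place of hydroxy on an aromatic carbon gives a 2.1-fold lower number from compound 2 to compound 3 (0.31 log units; beyond the scatter) and thus separates two compounds that differ only at this place. Against cyclohexyl, the 4-methylphenyl group gives a 2.7-fold lower number from compound 1 to compound 3 (0.44 log units; beyond the scatter) while the 4-hydroxyphenyl group gave only a 1.3-fold lower number from compound 1 to compound 2 (0.13 log units; within the scatter) within the scatter, so among these three compounds, an aromatic ring on the amine nitrogen does not by itself set the number and the group carried on that ring also counts. Both new steps are modest, and nothing available accounts for either of them.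

Only hydroxy and methyl are shown at this position, so it remains open whether the lower number of compound 3 follows from having methyl there or simply from losing hydroxy, a question that the unsubstituted phenyl group would address. Also open, on these data alone, is how far the trend extends to other groups at the same place, such as methoxy, chlorine or a longer chain like ethyl, and whether any of them would go beyond compound 3.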